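The source may report more compounds than this note shows. Statements on the series, on what has been measured and on what is new or still open speak of the compounds shown alone.

Compound 1 `CC1(C)[C@H]2CC[C@]1(C)N(Cc1cn(-c3ccccc3F)nn1)C(=O)C2`: 60 nM
Compound 2 `COc1ccccc1-n1cc(CN2C(=O)C[C@@H]3CC[C@@]2(C)C3(C)C)nn1`: 110 nM

In a functional assay on HepG2 cells (Homo sapiens) for inhibition, read by MTT assay, with a stated time of 24 h (a higher number here means a weaker inhibitor, a lower number a stronger inhibitor), compound 2 gives 110 nM, a number that cannot be told apart from that of compound 1. Compound 3 `CC1(C)[C@H]2CC[C@]1(C)N(Cc1cn(-c3cccc(O)c3)nn1)C(=O)C2` carries 3-hydroxyphenyl in place of 2-methoxyphenyl on an aromatic nitrogen. Going by the values given here, only one measured step bears on this change: a 1.8-fold higher number from compound 1 to compound 2 (0.26 log units; within the scatter). Among the compounds with values here, it stays within the scatter, but it is only a loose guide, since no measured compound carries a hydroxyl group. No step beyond the scatter is therefore expected in this assay, and no direction can be favoured. The expected change is a 1.1-fold lower number from compound 2 to compound 3 (0.04 log units; within the scatter). Compound 3 is estimated at 100 nM, with an expected range of 30 nM to 350 nM.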

Compound 3, half-maximal inhibitory concentration: 70 nM
The estimate for compound 3 lay 1.4-fold (0.15 log units) above the measured number, and the stated range covers the measured number.
By their numbers in this assay, from the lowest: compounds 1, 3 and 2 (each within the scatter of the next).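

In this assay the 3-hydroxyphenyl group on the aromatic nitrogen gives a 1.6-fold lower number from compound 2 to compound 3 (0.20 log units; within the scatter) and a 1.2-fold higher number from compound 1 to compound 3 (0.07 log units; within the scatter) and both steps lie within the scatter. This position therefore accepts a hydroxyl group, with its hydrogen-bond donor, which neither 2-methoxyphenyl nor 2-fluorophenyl carries, and the numbers cannot be told apart. No measurement here offers an explanation for this result.

On these data alone, what an amine or a carboxylic acid on this phenyl ring would do remains open. So does whether 2-hydroxyphenyl would match 3-hydroxyphenyl, since the group and its place on the ring change together here.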